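The source may report more compounds than this note shows. Statements on the series, on what has been measured and on what is new or still open speak of the compounds shown alone.

Working notes on the series. Compound 1 `O=C/C=C/c1ccccc1OCc1ccccc1` carries no chloro and in a functional assay on cells (Neutrophil, Rattus norvegicus, strain Sprague-Dawley) for inhibition (a lower number here means a stronger inhibitor, a higher number a weaker inhibitor), compound 1 gives 6400 nM. Compound 2 `O=C/C=C/c1ccccc1OCc1cccc(Cl)c1` gives 5900 nM in this assay; compound 3 `O=C/C=C/c1ccccc1OCc1ccc(Cl)cc1` gives 7400 nM, the highest of the three numbers, yet within the scatter of both others. Compound 4 `O=C/C=C/c1ccccc1OCc1ccc(Cl)c(Cl)c1` differs from compound 3 by chloro in place of hydrogen on an aromatic carbon. Within the data shown here, two measured steps bear on a chloro added to an aromatic carbon of this ring: a 1.1-fold lower number from compound 1 to compound 2 (0.04 log units; within the scatter) and a 1.2-fold higher number from compound 1 to compound 3 (0.06 log units; within the scatter), both within the scatter. A further chloro is therefore expected to leave the number in this assay near where compound 3 stands, with no step beyond the scatter in either direction. For compound 4 the expected step is a 1.1-fold lower number from compound 3 to compound 4 (0.02 log units; within the scatter). Compound 4 is estimated at 7000 nM, in a range from 3500 nM to 14000 nM.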

Compound 4, half-maximal inhibitory concentration: 4300 nM
Estimate against measurement, compound 4: 1.6-fold (0.21 log units) above; low and high end bracket the measured number.
By their numbers in this assay, from the lowest: compounds 4, 2, 1 and 3 (each within the scatter of the next).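

In this assay, a chloro placed ortho to a chloro group stays within the scatter from either compound with one chloro, with a 1.7-fold lower number from compound 3 to compound 4 (0.24 log units; within the scatter) and a 1.4-fold lower number from compound 2 to compound 4 (0.14 log units; within the scatter). The first of these steps does not differ measurably from the same change on the core of compound 1: the same change on two cores in this assay, a 1.1-fold lower number (0.04 log units; within the scatter) from compound 1 to compound 2 and a 1.7-fold lower number (0.24 log units; within the scatter) from compound 3 to compound 4, 1.6-fold (0.20 log units) apart, within the scatter of two such steps. The second step likewise agrees with its counterpart: the same change on two cores in this assay, a 1.2-fold higher number (0.06 log units; within the scatter) from compound 1 to compound 3 and a 1.4-fold lower number (0.14 log units; within the scatter) from compound 2 to compound 4, 1.6-fold (0.20 log units) apart, within the scatter of two such steps. Going by these compounds, whether an amine or a carboxylic acid on this ring would take the number beyond the scatter remains open.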